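This account rests on a few compounds, and the source may have more. Where it says the series, first, only, none or still open, it means among the compounds named here.

Measured so far in an ADME assay on microsomes from liver (Rattus norvegicus) for metabolic stability; on this read-out higher numbers stand for fast clearance and lower numbers for slow clearance:
- compound 1 `CNc1nc(NC2(C#N)CCCCC2)nc(-n2cccn2)n1`: 103 mL/min/kg
- compound 2 `CNc1nc(NC)nc(NC2(C#N)CCCCC2)n1`: 210 mL/min/kg
- compound 3 `CNc1nc(NC2(C#N)CCCCC2)nc(-n2ccnc2)n1`: 52 mL/min/kg

Compound 3 stands clear of the methylamino analogue, as a 4.0-fold lower number from compound 2 to compound 3 (0.61 log units; beyond the scatter) shows. It cannot be separated from the 1H-pyrazol-1-yl analogue, as a 2.0-fold lower number from compound 1 to compound 3 (0.30 log units; within the scatter) shows.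

Compound 4 `CNc1nc(NC2(C#N)CCCCC2)nc(N2CCCC2)n1` is not yet measured. It carries pyrrolidin-1-yl in place of 1H-imidazol-1-yl on an aromatic carbon. Among the measured compounds shown here, no measured compound has pyrrolidin-1-yl at this place. For the measured compounds named here, the nearest guide is compound 2, the only measured compound whose group there has no aromatic ring. Its modest step of a 4.0-fold lower number from compound 2 to compound 3 (0.61 log units; beyond the scatter), read in reverse, points upward in this assay, and a 2.0-fold higher number from compound 1 to compound 2 (0.31 log units; beyond the scatter) points the same way. This rests on one compound, so the expectation is loose. The expected step is a 3.7-fold higher number from compound 3 to compound 4 (0.56 log units; beyond the scatter). For compound 4 the estimated clearance is 190 mL/min/kg, with an expected range of 90 mL/min/kg to 400 mL/min/kg.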

Compound 4, clearance: > 276 mL/min/kg
Compound 4 was reported as a limit; the forecaster's own chance of this, stated with the estimate: 5%; middle value at least 1.4-fold (0.16 log units) from the limit.
By their numbers in this assay, from the lowest: compounds 3 and 1 (each within the scatter of the next); then compound 2. At a limit, above all of these: compound 4.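

In this assay, compound 4 is reported only as a limit: the limit of > 276 mL/min/kg in this assay, at which 1 of the 4 values shown sits.

Among the compounds shown here, this is the first sign that pyrrolidin-1-yl at this place is poorly tolerated compared with either aromatic five-membered ring (an at least 5.3-fold higher number from compound 3 to compound 4 (0.72 log units; beyond the scatter); an at least 2.6-fold higher number from compound 1 to compound 4 (0.42 log units; beyond the scatter)), and both steps are beyond the scatter. Against methylamino the floor is not informative (an at least 1.3-fold higher number from compound 2 to compound 4 (0.11 log units; that floor lies within the scatter)), so compound 4 and compound 2 cannot be separated, although across these four compounds the two without an aromatic ring at this place, compound 2 and compound 4, both give higher numbers than compound 1 and compound 3, and none goes against this.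

Going by these compounds, whether the aromatic ring itself or its hetero atoms matter stays open, as does how a phenyl or morpholin-4-yl group would read at this place. On these data alone, with compound 4 given only as a limit, the full size of its steps also stays open.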